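This account rests on a few compounds, and the source may have more. Where it says the series, first, only, none or still open, it means among the compounds named here.

Measured in an ADME assay on MT4 cells (Homo sapiens) for cytotoxicity; on this read-out lower numbers stand for higher toxicity in this test and higher numbers for lower toxicity in this test:
compound 1 `COC(=O)N[C@H](C(=O)NN(CCC[C@@](O)(Cc1ccccc1)C(=O)N[C@H]1c2ccccc2C[C@H]1O)Cc1ccc(Cl)cc1)C(C)(C)C`: > 10000 nM (limit)
compound 2 `COC(=O)N[C@H](C(=O)NN(CCC[C@@](O)(Cc1ccccc1)C(=O)N[C@H]1c2ccccc2C[C@H]1O)Cc1ccc(-c2ccccn2)cc1)C(C)(C)C`: > 10000 nM (limit)
compound 3 `COC(=O)N[C@H](C(=O)NN(CCC[C@@](O)(Cc1ccccc1)C(=O)N[C@H]1c2ccccc2C[C@H]1O)Cc1ccc(-c2noc(C)n2)cc1)C(C)(C)C`: > 10000 nM (limit)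

Compound 3 stands at > 10000 nM, which is a limit and not a number. The set as a whole shows (the limit of > 10000 nM in this assay, at which 3 of the 3 values shown sit).

The next change leads to compound 4 `COC(=O)N[C@H](C(=O)NN(CCC[C@@](O)(Cc1ccccc1)C(=O)N[C@H]1c2ccccc2C[C@H]1O)Cc1ccc(-c2nc(C(C)(C)C)cs2)cc1)C(C)(C)C`: 4-(tert-butyl)-1,3-thiazol-2-yl in place of 5-methyl-1,2,4-oxadiazol-3-yl on an aromatic carbon. In words, 4-(tert-butyl)-1,3-thiazol-2-yl takes the place of 5-methyl-1,2,4-oxadiazol-3-yl on an aromatic carbon, para to a large group.

Three measured changes at this same place bear on it: a step that the two limits leave unreadable from compound 1 to compound 2, a step that the two limits leave unreadable from compound 1 to compound 3 and a step that the two limits leave unreadable from compound 2 to compound 3. None of them yields a size or a direction, so they support no forecast of a real shift in this assay. The expectation of no step beyond the scatter rests on compound 3, whose limit is > 10000 nM. The expected step is a number no higher from compound 3 to compound 4 (the limit leaves the size open). The estimate for compound 4 is 10000 nM. The expected range for compound 4 runs from 4000 nM to 25000 nM.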

Compound 4, half-maximal cytotoxic concentration: > 10000 nM
Compound 4 gave a limit, no number (the forecaster's own chance of this, stated with the estimate: 75%); the middle value sits exactly at the limit.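

In this assay, within the data shown here, compound 4 gives only a limit, so no step among compound 1, compound 2, compound 3 and compound 4 can be read: the limit of > 10000 nM in this assay, at which 4 of the 4 values shown sit. The compounds shown leave open how far any of them lies past that limit, and whether any change at this aromatic carbon shifts the read-out.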